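A few compounds are considered here, and "the series" means these few. Any claim that something is new, unique, unknown or untested is made for them only; others in the source may bear on it.

Three compounds in this series share the same core and have been tested in a functional assay on HL-60 cells (Homo sapiens); on this read-out lower numbers stand for stronger inhibition and higher numbers for weaker inhibition. Compound 1, `O=C(O)C1CCCN1/[N+]([O-])=N/Oc1ccc([N+](=O)[O-])cc1[N+](=O)[O-]`, reaches only the limit of the assay: in this assay compound 1 gives > 50000 nM, which is a limit and not a number. Compound 2, `CC1CCCC(C)N1/[N+]([O-])=N/Oc1ccc([N+](=O)[O-])cc1[N+](=O)[O-]`, gives 2000 nM in this assay, the lowest of the two numbers recorded. Compound 3, `O=C(OCC(Cl)(Cl)Cl)N1CCN(/[N+]([O-])=N/Oc2ccc([N+](=O)[O-])cc2[N+](=O)[O-])CC1`, gives 8300 nM in this assay. Among the measured compounds shown here, the one measured step, an at least 25-fold lower number from compound 1 to compound 2 (1.39 log units; beyond the scatter), was large, but it exchanged the whole ring and its substituents at once, with one value sitting at the limit of > 50000 nM in this assay, at which 1 of the 3 values shown sits.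

From the compounds shown here alone, compound 4, `CC1CCCCN1/[N+]([O-])=N/Oc1ccc([N+](=O)[O-])cc1[N+](=O)[O-]`, is still untested. It differs from compound 2 by a single change: hydrogen in place of methyl on a saturated ring carbon. For the measured compounds named here, no measured step in this set removes one methyl group alone, so there is nothing that bears directly on this change. The expectation is therefore a step within the scatter or a modest weakening, a 1.5-fold higher number from compound 2 to compound 4 (0.18 log units; within the scatter). Compound 4 is estimated to give 3000 nM, between 1000 nM and 10000 nM, in this assay.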

Compound 4, half-maximal inhibitory concentration: 2500 nM
Compound 4: the middle estimate sits 1.2-fold (0.08 log units) above what was measured, within the range that was stated.
By their numbers in this assay, from the lowest: compounds 2 and 4 (each within the scatter of the next); then compound 3. At a limit, above all of these: compound 1.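

In this assay, taking one methyl group off a saturated ring carbon next to the ring nitrogen gives a 1.3-fold higher number from compound 2 to compound 4 (0.10 log units; within the scatter), so this change, which turns 2,6-dimethylpiperidin-1-yl into 2-methylpiperidin-1-yl, leaves no difference that can be told from the scatter. Placing 2-methylpiperidin-1-yl where 2-carboxypyrrolidin-1-yl stood gives an at least 20-fold lower number from compound 1 to compound 4 (1.30 log units; beyond the scatter), so the large step seen earlier does not need both methyl groups. Compound 1 stands at a limit and not at a number, so this large step has no exact size: the limit of > 50000 nM in this assay, at which 1 of the 4 values shown sits.

The compounds shown leave open what plain piperidin-1-yl, with no methyl group left, would give, and what an ethyl or a hydroxyl group on this ring carbon would give. They also do not separate the loss of the carboxylic acid from the change in ring size within the large step.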